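Oxadiazole series: cyano for methoxy at the aryl position

The source may hold more compounds than are shown below. What is called first, only, known or untested is meant among the compounds shown, and "the series" means these compounds.

Compound 2 `COc1cc(-c2c(C)nn(C)c2C)ccc1-c1nnc(N(C)Cc2ccc3nccn3c2)o1` gives 794 nM in an assay on isolated protein for inhibition of tyrosine-protein kinase receptor UFO (Homo sapiens), read by LC-MS (on this read-out higher numbers stand for weaker inhibition and lower numbers for stronger inhibition), and stands highest of the two numbers measured; its nearest neighbour is compound 1 `Cc1nn(C)c(C)c1-c1ccc(-c2nnc(N(C)Cc3ccc4nccn4c3)o2)c(Cl)c1`, which gives 79.4 nM in this assay. For the measured compounds named here, the only measured step is a 10-fold higher number from compound 1 to compound 2 (1.00 log units; beyond the scatter), the exchange of chloro for methoxy on an aromatic carbon. Compound 3 `Cc1nn(C)c(C)c1-c1ccc(-c2nnc(N(C)Cc3ccc4nccn4c3)o2)c(C#N)c1` carries the change (cyano in place of methoxy on an aromatic carbon), on an aromatic carbon of a six-membered aromatic ring of carbon only, ortho to a large group and meta to the 1,3,5-trimethyl-1H-pyrazol-4-yl group. Going by the values given here, that methoxy was the substituent linked to the weaker number suggests its removal should move the number back down, though no measured step tells how far cyano goes. The step from compound 2 to compound 3 is therefore expected to be a 4.0-fold lower number from compound 2 to compound 3 (0.60 log units; beyond the scatter), toward stronger inhibition. Compound 3 is estimated at 200 nM, with a range of 50 nM to 800 nM in this assay.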

Compound 3, half-maximal inhibitory concentration: > 100000 nM
Compound 3: only a limit was reported (the forecaster's own chance of this, stated with the estimate: 2%); middle value at least 500-fold (2.69 log units) away from the limit.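

In this assay this position, ortho to a large group, proves far more sensitive than the exchange of chloro for methoxy alone could show: the move to cyano gives an at least 120-fold higher number from compound 2 to compound 3 (2.10 log units; beyond the scatter) and, set against chloro, an at least 1200-fold higher number from compound 1 to compound 3 (3.10 log units; beyond the scatter). Methoxy and cyano count the same here, with 2 heavy atoms and 1 hydrogen-bond acceptor each, so these counts do not separate the two groups, while the read-out does. The value of compound 3, > 100000 nM, is a limit and not a number, so both steps give only a minimum size: the limit of > 100000 nM in this assay, at which 1 of the 3 values shown sits.

From the compounds shown here alone, whether chloro is the exception at this position or cyano alone is the outlier stays open, and fluoro, an amine or plain hydrogen here would help to decide it. Also open, going by these compounds, is whether the same order of groups holds with another group in place of the 1,3,5-trimethyl-1H-pyrazol-4-yl group.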